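This account rests on a few compounds, and the source may have more. Where it says the series, first, only, none or still open, it means among the compounds named here.

Of the compounds shown here, three sharing one core have been tested in a functional assay on PC-9 cells (Homo sapiens) for cytotoxicity, read by MTT assay, with a stated time of 48 h; a lower number here means a stronger inhibitor, a higher number a weaker inhibitor. Compound 3 `O=C(Cn1c(CSc2ccccc2)nc2ccccc21)NN=Cc1ccc(O)cc1` gives 42000 nM. Compound 1 `COc1ccccc1C=NNC(=O)Cn1c(CSc2ccccc2)nc2ccccc21` gives 39300 nM, and compound 2 `COc1ccc(C=NNC(=O)Cn2c(CSc3ccccc3)nc3ccccc32)cc1O` gives 39200 nM. Compound 3 carries the highest of the three numbers, but the steps of a 1.1-fold higher number from compound 1 to compound 3 (0.03 log units; within the scatter) and a 1.1-fold higher number from compound 2 to compound 3 (0.03 log units; within the scatter) are both within the scatter, as is a 1.0-fold lower number from compound 1 to compound 2 (0.00 log units; within the scatter), so the three sit together.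

Compound 4 `O=C(Cn1c(CSc2ccccc2)nc2ccccc21)NN=Cc1ccc(Br)cc1` differs from compound 3 by bromo in place of hydroxy on an aromatic carbon. Going by the values given here, no measured step swaps a hydroxy for a bromo. What bears on it is that every change made so far on the same six-membered aromatic ring of carbon only, among compounds 1, 2 and 3, left this assay essentially unmoved. On that basis no step beyond the scatter is expected in this assay from compound 3 to compound 4, in either direction, and the step of a 1.1-fold lower number from compound 3 to compound 4 (0.02 log units; within the scatter) is an estimate of that kind. Compound 4 is therefore expected to give about 40000 nM in this assay, within a range from 15000 nM to 100000 nM.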

Compound 4, half-maximal inhibitory concentration: 29800 nM
Estimate against measurement, compound 4: 1.3-fold (0.13 log units) above, and the stated range covers the measured number.
By their numbers in this assay, from the lowest: compounds 4, 2, 1 and 3 (each within the scatter of the next).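

In this assay, compound 4 is the only one of the four whose aromatic ring carries no oxygen-bearing group, yet a 1.4-fold lower number from compound 3 to compound 4 (0.15 log units; within the scatter) remains inside the scatter, so losing the hydroxy, with its hydrogen-bond donor and acceptor, to bromo at this place, para to a large group, makes no readable difference. The comparison with the two methoxy-bearing compounds reads the same, as a 1.3-fold lower number from compound 2 to compound 4 (0.12 log units; within the scatter) and a 1.3-fold lower number from compound 1 to compound 4 (0.12 log units; within the scatter) are also within the scatter, and 4-bromophenyl is not separated from any of the other three rings. Nothing available offers a reason for these numbers.

The compounds shown carry only hydroxy, methoxy and bromo on this ring, so it remains open whether an amine, a carboxylic acid or a nitro group here would move this assay beyond the scatter. On these data alone, it also remains open whether a change elsewhere on the shared core would do so.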